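The compounds below may be only part of what the source reports. "The series", "measured", "known", "first", "only" and "open" are said of these compounds alone.

Working notes on the series. In an ADME assay on MDCKII-LE cells (Canis lupus familiaris) for permeability (a higher number here means that the compound crosses the layer faster, a lower number that the compound crosses the layer more slowly), compound 1 `Cc1cnc(NC(=O)c2cc(Oc3cnc(C(=O)N(C)C)cn3)c3cc(C)oc3c2)cn1` gives 22.3 10^-6 cm/s, and compound 2 `Cc1cnc(NC(=O)c2cc(Oc3ccc(C(=O)N(C)C)nc3)c3cc(C)oc3c2)cn1` gives 28.5 10^-6 cm/s. For the measured compounds named here, these two numbers lie within the scatter of each other, so compound 1 stands level with the only other measured compound and the pair sets no order.

Compound 3 `Cc1cnc(NC(=O)c2cc(Oc3cnc(C(=O)N4CCCCC4)cn3)c3cc(C)oc3c2)cn1` keeps the core of compound 1 and carries piperidin-1-yl in place of dimethylamino on a carbonyl carbon. The change brings in one six-membered non-aromatic ring and leaves the molecule with no net charge.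

Going by the values given here, no measured pair shows this change, so the data give no direct size for it. The expectation therefore rests on compound 1 at 22.3 10^-6 cm/s as the starting point. In this assay, a slight upward move is expected, with nothing beyond the scatter as the likeliest outcome. The estimated move is a 1.1-fold higher number from compound 1 to compound 3 (0.05 log units; within the scatter). For compound 3 the estimated value is 25 10^-6 cm/s, with an expected range from 13 10^-6 cm/s to 45 10^-6 cm/s.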

Compound 3, apparent permeability: 13.3 10^-6 cm/s
Beside the measured number, compound 3's estimate is 1.9-fold (0.27 log units) above it; measured number inside the range.
By their numbers in this assay, from the lowest: compounds 3, 1 and 2 (each within the scatter of the next, the first and the last beyond it).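

In this assay, the step for piperidin-1-yl in place of dimethylamino on a carbonyl carbon reads a 1.7-fold lower number from compound 1 to compound 3 (0.22 log units; within the scatter), so this change stays within the scatter. For the compounds shown here, the earlier compounds both carry dimethylamino at this place, and compound 3 gives the first reading of another group there: a six-membered non-aromatic ring can enter at this carbonyl carbon without a step beyond the scatter, at least on the core of compound 1. Nothing on hand bears on what lies behind this step.

Going by these compounds alone, the single step does not show whether piperidin-1-yl would give a step of like size on the core of compound 2, so it cannot yet be read as a rule for this change across the series. Also open, from the compounds shown here alone, is how this assay would read with pyrrolidin-1-yl, morpholin-4-yl or diethylamino on the same carbonyl carbon, or with a group there that carries a free amine or a carboxylic acid.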